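A few compounds are considered here, and "the series" means these few. Any claim that something is new, unique, unknown or untested is made for them only; others in the source may bear on it.

Measured compounds in an assay on isolated protein for binding affinity to sphingosine 1-phosphate receptor 2 (Homo sapiens), read by surface plasmon resonance; on this read-out lower numbers stand for tighter binding and higher numbers for weaker binding:

compound 1 `Cc1nn(C)c2nc(NNC(=O)Nc3cc(Cl)nc(Cl)c3)cc(C3CC3)c12` — 3650 nM
compound 2 `Cc1nn(C)c2nc(NNC(=O)Nc3cc(Cl)nc(Cl)c3)cc(C3CCCCC3)c12` — 2010 nM
compound 3 `Cc1nn(C)c2nc(NNC(=O)Nc3cc(Cl)nc(Cl)c3)cc(-c3ccc(Cl)s3)c12` — 1980 nM

Compound 3 gives the lowest of the three numbers, but its gaps to both neighbours are within the scatter: a 1.0-fold lower number from compound 2 to compound 3 (0.01 log units; within the scatter) and a 1.8-fold lower number from compound 1 to compound 3 (0.27 log units; within the scatter). Compound 4 `Cc1cc(NNC(=O)Nc2cc(Cl)nc(Cl)c2)nc2c1c(C)nn2C` carries the change (methyl in place of 5-chlorothiophen-2-yl on an aromatic carbon). The two steps that bear on this position, a 1.8-fold lower number from compound 1 to compound 3 (0.27 log units; within the scatter) and a 1.0-fold lower number from compound 2 to compound 3 (0.01 log units; within the scatter), are both within the scatter, so the group at this carbon has not moved this assay beyond noise across cyclopropyl, cyclohexyl and 5-chlorothiophen-2-yl. Methyl is a smaller group than any of these, and compound 1 with cyclopropyl gave the highest number; compound 4 is therefore expected to sit near compound 1, with the step of a 1.8-fold higher number from compound 3 to compound 4 (0.25 log units; within the scatter) estimated as a modest rise, likely within the scatter. Estimated value for compound 4: 3500 nM, range 1500 nM to 8000 nM.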

Compound 4, dissociation constant: 11000 nM
Beside the measured number, compound 4's estimate is 3.1-fold (0.50 log units) below it; the whole stated range lies below it.
By their numbers in this assay, from the lowest: compounds 3, 2 and 1 (each within the scatter of the next); then compound 4.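

In this assay, among these compounds, this carbon is not indifferent to its group: methyl is the first change here to pass the scatter, whether it replaces 5-chlorothiophen-2-yl (a 5.6-fold higher number from compound 3 to compound 4 (0.74 log units; beyond the scatter)), cyclohexyl (a 5.5-fold higher number from compound 2 to compound 4 (0.74 log units; beyond the scatter)) or cyclopropyl (a 3.0-fold higher number from compound 1 to compound 4 (0.48 log units; beyond the scatter)). The three ring-bearing groups stay within the scatter of one another, so the separation appears only between them and methyl. No measurement shown explains this separation.

Still open, from the compounds shown here alone, is how ethyl or isopropyl at this carbon would read, and so where between methyl and cyclopropyl the number changes. An amine or a carboxylic acid here is also untested among the compounds shown.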